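The compounds below may be only part of what the source reports. "The series", "measured", "known", "first", "only" and "open" are said of these compounds alone.

Measured compounds in a physicochemical assay for solubility, read by HPLC; a higher number here means a more soluble compound, a lower number a less soluble compound:

Compound 1, `CC(=O)NC[C@H]1CN(c2ccc(OC[C@@H](O)CNc3ccccn3)c(F)c2)C(=O)O1`: compound 1 gives 22200000 nM
Compound 2, `CC(=O)NC[C@H]1CN(c2ccc(OC[C@@H]3CN(c4ccccc4)C(=O)O3)c(F)c2)C(=O)O1`: compound 2 gives 14000 nM

Compound 2 stands as the lower of the two numbers in this assay. Compound 1 lies far above it, and the gap is well beyond the scatter of repeated measurements.

The next compound, compound 3 `CC(=O)NC[C@H]1CN(c2ccc(OC[C@H]3CN(c4ccccc4)C(=O)O3)c(F)c2)C(=O)O1`, differs from compound 2 as follows: the two compounds have the same atoms and bonds and differ only in configuration as drawn: 1 of 2 stereo elements differ; a stereocentre at a saturated ring carbon is drawn S in compound 2 and R in compound 3. Going by the values given here, no step between two measured compounds of this kind is available here, so the expectation rests on the change alone: a change of configuration at one saturated ring carbon with no atom leaving or entering.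

For compound 3 the expected step from compound 2 is small and without a settled direction, estimated as no change at the digits printed from compound 2 to compound 3 (within the scatter), likely within the scatter. Compound 3 is therefore expected to give about 14000 nM in this assay, within a range from 5000 nM to 40000 nM.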

Compound 3, solubility: 164000 nM
The estimate for compound 3 lay 12-fold (1.07 log units) below the measured number; the measured number lies above the stated range.
By their numbers in this assay, from the lowest: compound 2; then compound 3; then compound 1.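

In this assay, inverting one saturated ring carbon from S to R, with nothing leaving or entering, gives a 12-fold higher number from compound 2 to compound 3 (1.07 log units; beyond the scatter). Going by these compounds alone, compound 1 and compound 2 differ in more than one place, so they offered no reading of a single position; this pair is the only step so far that does. It shows that configuration at this ring carbon alone is enough to move the read-out well beyond the scatter, and the step can be assigned to that stereocentre: the fact that compounds 2 and 3 differ only in the configuration as drawn

On these data alone, this is a single pair, so it remains open whether the step keeps its size and direction in compounds carrying another group at this part of the molecule, such as a carboxylic acid or an amine. As far as these compounds go, the effect of inverting the second stereocentre, drawn the same in compound 2 and compound 3, also remains open.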